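Swapping a small ring for an aromatic heterocycle on the carbonyl

The compounds below may be only part of what the source reports. "The series", "measured", "known", "first", "only" and "open" are said of these compounds alone.

Measured compounds:
- Compound 1, `Cc1nc(S(C)(=O)=O)ccc1Oc1ncnc(OC2CCN(C(=O)OC(C)(C)C#N)CC2)c1F`: 97%
- Compound 2, `Cc1nc(S(C)(=O)=O)ccc1Oc1ncnc(OC2CCN(C(=O)O[C@H](C)CF)CC2)c1F`: 79%
- Compound 3, `Cc1nc(S(C)(=O)=O)ccc1Oc1ncnc(OC2CCN(C(=O)C3(F)CCC3)CC2)c1F`: 91%

All three share one core and differ only in the group attached to the carbonyl carbon. In a functional assay on isolated protein for inhibition of Glucose-dependent insulinotropic receptor (Rattus norvegicus), read by HTRF and cAMP accumulation (on this read-out higher numbers stand for larger maximal responses and lower numbers for smaller maximal responses), compound 3 gives 91%, the second highest of the three numbers. Its nearest neighbour is compound 1, and the step of a number 6 percentage points lower from compound 1 to compound 3 (within the scatter) stays within the scatter, so these two cannot be told apart. The step of a number 12 percentage points higher from compound 2 to compound 3 (beyond the scatter) is beyond the scatter, but modest, and the step of a number 18 percentage points lower from compound 1 to compound 2 (beyond the scatter) is of similar size.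

Compound 4, `Cc1nc(S(C)(=O)=O)ccc1Oc1ncnc(OC2CCN(C(=O)c3noc(C(C)(C)F)n3)CC2)c1F`, has not yet been measured. The change from compound 3 is a group of 9 heavy atoms (5 carbon, 2 nitrogen, 1 oxygen, 1 fluorine; one five-membered aromatic ring with 3 hetero atoms) in place of a group of 5 heavy atoms (4 carbon, 1 fluorine; one four-membered non-aromatic ring of carbon only), on a carbonyl carbon. Only the two steps at the carbonyl carbon bear on it, and both were modest or within the scatter, so a change of that order in this assay is expected here as well, with no clear direction; the group entering is larger than any tried before, which adds uncertainty. For compound 4 the expected value is 88%, between 70% and 102%, so the estimated step is a number 3 percentage points lower from compound 3 to compound 4 (within the scatter).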

Compound 4, largest response reached (reported as efficacy), in percent of the reference or control that the assay uses: 74%
For compound 4 the middle estimate is 14 percentage points above the measured one; measured number inside the range.
By their numbers in this assay, from the lowest: compounds 4 and 2 (each within the scatter of the next); then compounds 3 and 1 (each within the scatter of the next).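

Placing the group of 9 heavy atoms, the largest yet on this carbonyl carbon and the only one with a five-membered aromatic ring, gives in this assay both a number 17 percentage points lower from compound 3 to compound 4 (beyond the scatter) and a number 23 percentage points lower from compound 1 to compound 4 (beyond the scatter), the second being the widest gap seen at this position, though still modest. Heavy-atom count alone does not order these results: the larger group shows a number 5 percentage points lower from compound 2 to compound 4 (within the scatter) when it replaces a group of 5 heavy atoms, yet two different groups of 5 heavy atoms show a number 12 percentage points higher from compound 2 to compound 3 (beyond the scatter) despite their equal size. Across these four compounds, then, the response depends on more than the size of the group on the carbonyl carbon, and a sizeable maximal response persists even with the large aromatic group in place.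

Nothing shown explains why these groups differ in this way. Also open, going by these compounds, is how a plain phenyl ring, a primary amine or a longer alkyl chain on the same carbonyl carbon would compare, and whether the fluorine on the aromatic group's side chain matters to the result.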